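The source may hold more compounds than are shown below. What is called first, only, known or untested is meant among the compounds shown, and "the series" means these compounds.

Measured compounds:
- compound 1, `Cc1c(Nc2nc(N)c3c(C#N)c(N4CCC[C@H]4C)n(C)c3n2)cnn1CC(C)(C)O`: 35 nM
- compound 2, `C[C@@H]1CCCN1c1c(C#N)c2c(N)nc(Nc3cn(C)nc3Cl)nc2n1C`: 21 nM
- compound 3, `C[C@@H]1CCCN1c1c(C#N)c2c(N)nc(Nc3cn(C)nc3C(F)(F)F)nc2n1C`: 358 nM

All three share the same core and differ only in the pyrazole group attached through a nitrogen. In an assay on isolated protein for inhibition of Leucine-rich repeat serine/threonine-protein kinase 2 variant G2019S (Homo sapiens), read by TR-FRET and LanthaScreen, with stated times of 50 min and 30 min, in the presence of a further agent that is not named here (a lower number here means a stronger inhibitor, a higher number a weaker inhibitor), compound 3 gives the highest number of the three, so it is the weakest inhibitor shown: compound 1 sits well below it, and compound 2 lies even lower, both differences being beyond the usual scatter.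

The unmeasured compound 4, `Cc1c(Nc2nc(N)c3c(C#N)c(N4CCC[C@H]4C)n(C)c3n2)cnn1C1COC1`, differs from compound 3 in one place: 5-methyl-1-(oxetan-3-yl)-1H-pyrazol-4-yl in place of 1-methyl-3-(trifluoromethyl)-1H-pyrazol-4-yl on a nitrogen on an aromatic ring.

Among the compounds with values here, only one measured step bears on this directly. The step of a 17-fold higher number from compound 2 to compound 3 (1.23 log units; beyond the scatter) shows that bringing in the trifluoromethyl costs a great deal of potency; compound 4 removes it again. Compound 4 carries the same 5-methyl pyrazole as compound 1, though with a different group on its ring nitrogen. In this assay compound 1 gives 35 nM, a number close to that of compound 2. Taken together, the numbers point to a large step downward, that is a stronger inhibitor, and compound 4 is therefore expected to come out near compound 1, with a step of a 9.0-fold lower number from compound 3 to compound 4 (0.95 log units; beyond the scatter). The estimate for compound 4 is 40 nM, with a range from 15 nM to 120 nM.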

Compound 4, half-maximal inhibitory concentration: 37 nM
For compound 4 the middle estimate is 1.1-fold (0.03 log units) above the measured one, and the stated range covers the measured number.
By their numbers in this assay, from the lowest: compounds 2, 1 and 4 (each within the scatter of the next); then compound 3.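

Swapping the whole pyrazole group takes the number down by a wide margin in this assay, with a 9.7-fold lower number from compound 3 to compound 4 (0.99 log units; beyond the scatter), and the reading now sits level with that of the chloro compound, as a 1.8-fold higher number from compound 2 to compound 4 (0.25 log units; within the scatter) lies within the scatter; a pyrazole group without chlorine can therefore match the chloro group here, which compound 1 alone had suggested but which the ring nitrogen's new group now confirms. The new information at this position is that the group on the ring nitrogen can be exchanged with no visible effect: a 1.1-fold higher number from compound 1 to compound 4 (0.02 log units; within the scatter), also within the scatter, puts oxetan-3-yl, a four-membered ring, in place of the open 2-hydroxy-2-methylpropyl chain. Nothing measured here explains these steps.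

The step from compound 3 to compound 4 changes several features at once, leaving the separate shares of the departing trifluoromethyl, the 5-methyl and the oxetan-3-yl unresolved. Also open, from the compounds shown here alone, is how the number would respond to a piperidin-4-yl group, which carries an amine, or to a longer chain ending in a carboxylic acid on that ring nitrogen.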